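The source may hold more compounds than are shown below. What is called first, only, known or untested is meant among the compounds shown, and "the series" means these compounds.

Within the data shown here, the three compounds measured so far are compound 1 `Clc1ccc(-c2nc(NCCNc3ccccn3)ncc2-c2ncc[nH]2)c(Cl)c1`, compound 2 `Nc1nc(NCCNc2ncc(-c3ncc[nH]3)c(-c3ccc(Cl)cc3)n2)ccc1[N+](=O)[O-]` and compound 3 `Nc1nc(NCCNc2ncc(-c3ncc[nH]3)c(-c3ccc(F)cc3Cl)n2)ccc1[N+](=O)[O-]`. In an ADME assay on microsomes from liver (Canis lupus familiaris) for metabolic stability (on this read-out higher numbers stand for a longer-lived compound and lower numbers for a shorter-lived compound), compound 1 gives > 0.5 h, which is a limit of the assay and not a number. In this assay compound 2 gives > 0.5 h, again a limit. In this assay compound 3 gives > 0.5 h, also a limit, so its standing cannot be told more closely than this: it sits at the limit of > 0.5 h in this assay, at which 3 of the 3 values shown sit. Among the measured compounds shown here, the one step between measured compounds that differ in a single place, a step that the two limits leave unreadable from compound 2 to compound 3, touches the same aromatic carbon that is changed now, but its size cannot be read. Compound 4 `Cc1ccc(-c2nc(NCCNc3ccc([N+](=O)[O-])c(N)n3)ncc2-c2ncc[nH]2)c(Br)c1` is not yet measured; it differs from compound 3 in one place: 2-bromo-4-methylphenyl in place of 2-chloro-4-fluorophenyl on an aromatic carbon. For the measured compounds named here, the only related step carries no readable size. No direction or size can therefore be drawn from the measured steps for the change to compound 4. Compound 4 is therefore expected to sit at the same limit, its estimated half-life being 1.5 h, within 0.5 h to 6 h. The expected step is a step that the limit leaves unreadable from compound 3 to compound 4.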

Compound 4, half-life: > 0.5 h
Compound 4 was reported as a limit; the forecaster's own chance of this, stated with the estimate: 80%; the middle value is on the limit's open side.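

In this assay, compound 2, compound 3 and compound 4 each give only a limit, so neither step to compound 4 can be read: the limit of > 0.5 h in this assay, at which 4 of the 4 values shown sit. The compounds shown leave open each one's actual half-life, and so whether swapping these aromatic groups changes it at all.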